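Shortening the Alkyl on the Ring Nitrogen: Pentyl to Isopropyl

A few compounds are considered here, and "the series" means these few. Any claim that something is new, unique, unknown or untested is made for them only; others in the source may bear on it.

Going by the values given here, compound 1 `CCCCCn1nc2oc(=O)cc(C)c2c1C` was tested in a functional assay on the whole organism with Mus musculus as the target, in the writhing test (a higher number here means that more compound is needed for the effect, a lower number that less compound is needed), where compound 1 gives 60.6 mg/kg, the only number reported in this assay. Compound 2 `Cc1cc(O)oc2nnc(CC(=O)O)c1-2` sits at the limit of > 100 mg/kg in this assay, at which 1 of the 2 values shown sits, so its value > 100 mg/kg is a limit of the assay and not a number. Compound 3 `Cc1cc(=O)oc2nn(C(C)C)c(C)c12` differs from compound 1 by isopropyl in place of pentyl on an aromatic nitrogen. Among the compounds with values here, no measured pair shows this change, so its size is unknown; a step not beyond the usual scatter is expected. For compound 3 the expected value in this assay is 60 mg/kg, between 25 mg/kg and 150 mg/kg. This implies an expected step of a 1.0-fold lower number from compound 1 to compound 3 (0.00 log units; within the scatter).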

Compound 3, dose for half-maximal effect: 35.3 mg/kg
Compound 3: middle estimate off by 1.7-fold (0.23 log units), on the high side; the measured number falls inside the stated range.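

Isopropyl in place of pentyl on an aromatic nitrogen gives a 1.7-fold lower number from compound 1 to compound 3 (0.23 log units; within the scatter) in this assay for the first measured step at this position. Compound 1 and compound 3 therefore cannot be told apart in this read-out, so this exchange of one alkyl group for another leaves the effect dose unresolved. Nothing measured here bears on a cause for this step.

On these data alone, whether a longer chain, a benzyl group or a chain carrying an amine on this nitrogen would move the number beyond the scatter stays open. As far as these compounds go, the effect of a free hydrogen on this nitrogen also remains unknown.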